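The compounds below may be only part of what the source reports. "The series", "measured", "known", "first", "only" and "open" are said of these compounds alone.

Working notes on the series

Compound 1, `O=C(O)CS(=O)(=O)c1ccc(OCc2cccc(-c3ccccc3)c2)cc1`: 288 nM
Compound 2, `CC(C)c1ccccc1-c1cccc(COc2ccc(S(=O)(=O)CC(=O)O)cc2)c1`: 74.1 nM

Both numbers come from a functional assay on CHO cells for agonist activity at Free fatty acid receptor 1 (Homo sapiens), read by FLIPR and calcium flux; on this read-out lower numbers stand for an effect already at smaller amounts and higher numbers for an effect only at larger amounts of compound. Among the measured compounds shown here, compound 2 stands at the lowest number of the two measured so far; its only neighbour is compound 1, and the single measured step, a 3.9-fold lower number from compound 1 to compound 2 (0.59 log units; beyond the scatter), came with isopropyl in place of hydrogen on an aromatic carbon.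

Compound 3, `CCOc1ccc(-c2cccc(COc3ccc(S(=O)(=O)CC(=O)O)cc3)c2)c(Cl)c1`, differs from compound 2 by 2-chloro-4-ethoxyphenyl in place of 2-isopropylphenyl on an aromatic carbon. For the measured compounds named here, the step from compound 1 to compound 2 bears on this only in part: it shows that a group on this ring moved the number beyond the scatter, but no measured pair says how 2-chloro-4-ethoxyphenyl compares with 2-isopropylphenyl. With a substituted ring kept, a step no larger than the scatter is expected in this assay. Compound 3 is therefore estimated at 60 nM, with a range of 20 nM to 200 nM. The expected step is a 1.2-fold lower number from compound 2 to compound 3 (0.09 log units; within the scatter).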

Compound 3, half-maximal effective concentration: 51.3 nM
For compound 3 the middle estimate is 1.2-fold (0.07 log units) above the measured one; the range from low to high includes it.
By their numbers in this assay, from the lowest: compounds 3 and 2 (each within the scatter of the next); then compound 1.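

In this assay, replacing 2-isopropylphenyl with 2-chloro-4-ethoxyphenyl gives a 1.4-fold lower number from compound 2 to compound 3 (0.16 log units; within the scatter), so two substituted rings with different atoms cannot be told apart at this position. Against the plain phenyl, the same change gives a 5.6-fold lower number from compound 1 to compound 3 (0.75 log units; beyond the scatter); a step beyond the scatter from phenyl is therefore no longer seen with 2-isopropylphenyl alone, but holds for both substituted rings shown, with neither compound 2 nor compound 3 going against it. No supporting data are available that could explain either step.

The compounds shown leave open how much of the step from phenyl belongs to the chlorine and how much to the ethoxy, as the two enter together. Also open, on these data alone, is how an amine, a carboxylic acid or a chain longer than ethoxy on this ring would read in this assay.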